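The source may hold more compounds than are shown below. What is called first, only, known or untested is meant among the compounds shown, and "the series" means these compounds.

Working notes on the series. Compound 2 `CCc1ccc2nc(C(=O)Nc3c(F)cc(-c4cccc(F)c4)cc3F)c(C)c(O)c2c1` in a functional assay on Hep 3B2 cells (Homo sapiens) for antiproliferative activity, read by MTT assay, with a stated time of 24 h (a higher number here means a weaker inhibitor, a lower number a stronger inhibitor), gives 15800 nM. Compound 1 `Cc1ccc2nc(C(=O)Nc3c(F)cc(-c4cccc(F)c4)cc3F)c(C)c(O)c2c1` in this assay reaches only a limit of the assay, > 100000 nM. The step of an at least 6.3-fold higher number from compound 2 to compound 1 (0.80 log units; beyond the scatter) follows from hydrogen in place of methyl on a saturated chain carbon bound to an aromatic carbon; because compound 1 sits at the limit of > 100000 nM in this assay, at which 1 of the 3 values shown sits, only a lower bound of that step is in hand. Compound 3 `CCOc1ccc2nc(C(=O)Nc3c(F)cc(-c4cccc(F)c4)cc3F)c(C)c(C(=O)O)c2c1` carries a different core from compound 2; the difference between the two cores is not broken down here. In this assay compound 3 gives 5800 nM, the lowest of the two numbers, with compound 2 the nearest and that gap beyond the scatter. Compound 4 `COc1ccc2nc(C(=O)Nc3c(F)cc(-c4cccc(F)c4)cc3F)c(C)c(C(=O)O)c2c1` is not yet measured. It differs from compound 3 by hydrogen in place of methyl on a saturated chain carbon bound to an oxygen on an aromatic ring. This is the same kind of change as that from compound 2 to compound 1, but the place differs: there the carbon was bound to an aromatic carbon, here it is bound to an oxygen on an aromatic ring. A loss of potency of comparable direction is expected, with the size uncertain. Compound 4 is estimated at 20000 nM, expected between 7000 nM and 80000 nM, an expected step of a 3.4-fold higher number from compound 3 to compound 4 (0.54 log units; beyond the scatter). This expectation rests on an at least 6.3-fold higher number from compound 2 to compound 1 (0.80 log units; beyond the scatter).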

Compound 4, half-maximal inhibitory concentration: 14300 nM
Beside the measured number, compound 4's estimate is 1.4-fold (0.15 log units) above it; the range from low to high includes it.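

In this assay, the change from ethoxy to methoxy on the core of compound 3 gives a 2.5-fold higher number from compound 3 to compound 4 (0.39 log units; beyond the scatter), and this runs in the same direction as the change from ethyl to methyl on the core of compound 2, so the loss of the methyl carries across these two pairs in direction: the same change on two cores in this assay, an at least 6.3-fold higher number (0.80 log units; beyond the scatter) from compound 2 to compound 1 and a 2.5-fold higher number (0.39 log units; beyond the scatter) from compound 3 to compound 4; the limit leaves it open whether they differ. Compound 1 gives a limit of the assay and not a number: the limit of > 100000 nM in this assay, at which 1 of the 4 values shown sits. The size of the change therefore cannot be said to carry from one core to the other, and two pairs that also differ in the place of the change, a carbon bound to an aromatic carbon in one and to an oxygen on an aromatic ring in the other, show a shared direction, not a rule for the series.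

The compounds shown leave open how ethyl and methyl would read on the core of compound 3, and how ethoxy and methoxy would read on the core of compound 2. They also leave open whether a longer chain such as propoxy, or an amine in the same place, would continue this direction.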